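Quinolin-7-yl Sulfonamide: Expected Maximal Response

The compounds below may be only part of what the source reports. "The series", "measured", "known", "first", "only" and "open" are said of these compounds alone.

Measured compounds:
Compound 1, `CCN(Cc1ccccc1)C(=O)C1CCN(S(=O)(=O)c2cccc(OC)c2)CC1`: 77%
Compound 2, `CCN(Cc1ccccc1)C(=O)C1CCN(S(=O)(=O)c2ccc(C)s2)CC1`: 64%
Compound 3, `CCN(Cc1ccccc1)C(=O)C1CCN(S(=O)(=O)c2ccc(C(F)(F)F)nc2)CC1`: "not determined" (no result reported)

All three share one core, a piperidine amide carrying a sulfonyl group whose aryl part varies. Among the measured compounds shown here, in a functional assay on CHO cells for positive allosteric modulation of muscarinic acetylcholine receptor M5 (Homo sapiens), read by calcium flux (a higher number here means a larger maximal response, a lower number a smaller maximal response), compound 1 gives 77% and compound 2 gives 64%; the only measured step is a number 13 percentage points lower from compound 1 to compound 2 (beyond the scatter). Going by these compounds, for compound 3 the entry in this assay reads "not determined" (no result reported), so its standing is unknown.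

Compound 4, `CCN(Cc1ccccc1)C(=O)C1CCN(S(=O)(=O)c2ccc3cccnc3c2)CC1`, differs from compound 3 in one place: quinolin-7-yl in place of 6-(trifluoromethyl)pyridin-3-yl on a sulfonyl sulfur. For the measured compounds named here, the one measured step bears on this change only loosely, since it also swaps the aryl group on the sulfonyl sulfur, and there it moved the maximal response by a modest amount. With no value for compound 3, the expectation rests on the spread seen between compound 1 and compound 2 alone. Compound 4 is therefore expected to give about 70% in this assay, with a range from 50% to 90%.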

Compound 4, largest response reached (reported as percent of maximum), in percent of the reference or control that the assay uses: 66%
The estimate for compound 4 lay 4 percentage points above the measured number; the measured number falls inside the stated range.
By their numbers in this assay, from the lowest: compounds 2 and 4 (each within the scatter of the next); then compound 1.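

In this assay, quinolin-7-yl on the sulfonyl sulfur still gives a clear maximal response, so this position is not limited to the single-ring groups of compound 1 and compound 2. Quinolin-7-yl in place of 5-methylthiophen-2-yl leaves the two groups indistinguishable (a number 2 percentage points higher from compound 2 to compound 4 (within the scatter)), while quinolin-7-yl in place of 3-methoxyphenyl gives a real drop (a number 11 percentage points lower from compound 1 to compound 4 (beyond the scatter)), which leaves compound 1 with the largest response of the three compounds with values. No measurement offered here accounts for these differences.

The step from compound 3 to compound 4 cannot be read, since compound 3 has no value. Also open, going by these compounds, is whether an aryl group carrying an amine or a carboxylic acid, or a plain alkyl chain, on the sulfonyl sulfur would keep this response.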